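The compounds below may be only part of what the source reports. "The series", "measured", "known", "first", "only" and "open" are said of these compounds alone.

Measured in an ADME assay on KB cells (Homo sapiens) for cytotoxicity; on this read-out higher numbers stand for an effect only at larger amounts of compound and lower numbers for an effect already at smaller amounts (limits of the assay are marked as such)
- compound 1 `COc1cc2c(c(OCc3ccccc3)c1OC)C(=O)[C@]1(OC)C=C[C@H]2N(C(=O)OCC(C)C)N1C(=O)OCC(C)C` gives 94 ug/mL (a number)
- compound 2 `COc1cc2c(c(OC)c1OC)C(=O)[C@]1(OC)C=C[C@H]2N(C(=O)OCC(C)C)N1C(=O)OCC(C)C` gives > 300 ug/mL (a limit)
- compound 3 `COc1cc2c(c(OCc3ccc(F)cc3)c1OC)C(=O)[C@]1(OC)C=C[C@H]2N(C(=O)OCC(C)C)N1C(=O)OCC(C)C` gives > 300 ug/mL (a limit)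

For compound 3, the entry > 300 ug/mL is a limit and not a number. This position is the limit of > 300 ug/mL in this assay, at which 2 of the 3 values shown sit, and compound 2 shares it.

Compound 4 `CCCCOc1c(OC)c(OC)cc2c1C(=O)[C@]1(OC)C=C[C@H]2N(C(=O)OCC(C)C)N1C(=O)OCC(C)C` differs from compound 3 as follows: propyl in place of 4-fluorophenyl on a saturated chain carbon bound to an oxygen on an aromatic ring. Put simply, 4-fluorobenzyl gives way to butyl.

For the measured compounds named here, two measured steps bear on this change. The first is an at least 3.1-fold higher number from compound 1 to compound 2 (0.50 log units; beyond the scatter), and the second is an at least 3.1-fold higher number from compound 1 to compound 3 (0.50 log units; beyond the scatter). Going by these compounds, both lie beyond the scatter, and both end at the limit, so their full size is unknown. The third, a step that the two limits leave unreadable from compound 2 to compound 3, cannot be read.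

Only compound 1 gives a number, so there is little to go on, and a result close to the limit seems likely. The expected change is an at least 1.2-fold lower number from compound 3 to compound 4 (0.07 log units; that floor lies within the scatter), small and at most a modest move to a lower number. For compound 4 the estimated value is 250 ug/mL, with an expected range from 90 ug/mL to 600 ug/mL.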

Compound 4, concentration for half-maximal effect: 22.1 ug/mL
Estimate against measurement, compound 4: 11-fold (1.05 log units) above; the measured number lies below the stated range.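

Until now only the benzyl group of compound 1 gave a number in this assay, so an aromatic ring at this position might have seemed necessary, but compound 4 shows that a butyl chain on the oxygen also gives a measurable effect, and a stronger one, with a 4.3-fold lower number from compound 1 to compound 4 (0.63 log units; beyond the scatter). Butyl also stands well apart from 4-fluorobenzyl, with an at least 13-fold lower number from compound 3 to compound 4 (1.13 log units; beyond the scatter), and from methoxy, with an at least 13-fold lower number from compound 2 to compound 4 (1.13 log units; beyond the scatter). Compound 2 and compound 3 each give a limit and not a number, so these two steps have only a minimum size and the step between those compounds cannot be read: the limit of > 300 ug/mL in this assay, at which 2 of the 4 values shown sit.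

The compounds shown leave open whether a longer chain such as hexyl would lower the number further or raise it again. They also leave open how a chain ending in an amine would behave at this position.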